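A few compounds are considered here, and "the series" means these few. Any claim that something is new, unique, unknown or untested is made for them only; others in the source may bear on it.

Compound 1 `Cc1ccc(CNc2nc(Nc3ccc(N4CCN(C)CC4)cn3)ncc2Cl)cc1` gives 38100 nM
Compound 2 `CN1CCN(c2ccc(Nc3ncc(Cl)c(NCc4ccco4)n3)nc2)CC1` gives 21300 nM
Compound 3 `Cc1ccc(Nc2nc(Nc3ccc(N4CCN(C)CC4)cn3)ncc2Cl)cc1` gives 11400 nM

These numbers come from a functional assay on MCF7 cells (Homo sapiens) for inhibition, read by CCK-8 assay, with a stated time of 48 h (on this read-out higher numbers stand for weaker inhibition of growth and lower numbers for stronger inhibition of growth), and compound 3 stands clear of only one of the other two. The steps that reach it are a 3.3-fold lower number from compound 1 to compound 3 (0.52 log units; beyond the scatter) and a 1.9-fold lower number from compound 2 to compound 3 (0.27 log units; within the scatter) and both alter the group on a nitrogen on an aromatic ring. Going by the values given here, compound 4 `CC(C)c1ccccc1Nc1nc(Nc2ccc(N3CCN(C)CC3)cn2)ncc1Cl` has 2-isopropylphenyl in place of 4-methylphenyl at that place 2-isopropylphenyl in place of 4-methylphenyl on a nitrogen on an aromatic ring and no measured compound carries this group. With compound 3 at 11400 nM and steps of only that size, no step beyond the scatter is expected. The expected step is a 1.3-fold lower number from compound 3 to compound 4 (0.10 log units; within the scatter) in this read-out. For compound 4 the estimated value is 9000 nM with an expected range from 3000 nM to 25000 nM here.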

Compound 4, concentration for 50% growth inhibition: 4360 nM
For compound 4 the middle estimate is 2.1-fold (0.31 log units) above the measured one; measured number inside the range.
By their numbers in this assay, from the lowest: compound 4; then compounds 3, 2 and 1 (each within the scatter of the next, the first and the last beyond it).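

In this assay the group on a nitrogen on an aromatic ring still matters among phenyl groups attached directly there: 2-isopropylphenyl in place of 4-methylphenyl gives a 2.6-fold lower number from compound 3 to compound 4 (0.42 log units; beyond the scatter), a step beyond the scatter. Going by these compounds alone, the same group gives a 4.9-fold lower number from compound 2 to compound 4 (0.69 log units; beyond the scatter) and an 8.7-fold lower number from compound 1 to compound 4 (0.94 log units; beyond the scatter), which widens the spread seen among the earlier compounds. No supporting measurement explains this change.

The compounds shown leave open how a cyclohexyl group, or a phenyl ring carrying an amine or a carboxylic acid, would behave at this place.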